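The compounds below may be only part of what the source reports. "The series", "measured", "known", "first", "only" and "open" are said of these compounds alone.

In a functional assay on EA.hy 926 cells (Homo sapiens), read by fluorescence, tested at 1 uM (a lower number here means a weaker effect, a higher number a stronger effect of the compound at the concentration tested), three compounds have been measured. Compound 1, `COc1cc(/C=C/C(=O)/C=C(/C=C/c2ccc(OC(C)=O)c(OC)c2)NC2CCCCC2)ccc1OC(C)=O`, gives 101%. Compound 2, `CCC(C)NC(=C\C(=O)/C=C/c1ccc(O)cc1)/C=C/c1ccc(O)cc1`, gives 99%. Compound 3, `CCC(C)NC(=C\C(=O)/C=C/c1ccc(OC(C)=O)c(OC)c1)/C=C/c1ccc(OC(C)=O)c(OC)c1`, gives 68%. Compound 1 and compound 3 share a core and differ in one place, (cyclohexyl in place of sec-butyl on an amine nitrogen); that change makes a number 33 percentage points higher from compound 3 to compound 1 (beyond the scatter). The core of compound 2 differs from that of compound 3, but the difference between the two cores is not broken down here; their numbers simply show compound 2 well above compound 3. Going by the values given here, compound 4, `O=C(/C=C(/C=C/c1ccc(O)cc1)NC1CCCCC1)/C=C/c1ccc(O)cc1`, has not yet been measured; it differs from compound 2 by cyclohexyl in place of sec-butyl on an amine nitrogen, which is the same change as the one from compound 3 to compound 1. Compound 2 already stands near the top of the scale because of 99%, so the step from compound 2 to compound 4 is expected to be far smaller than the earlier one, roughly a number 1 percentage points higher from compound 2 to compound 4 (within the scatter). The estimate for compound 4 in this assay is therefore 100%, expected to fall between 90% and 106%.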

Compound 4, a percentage reported as activity, at one concentration (the size of the read-out at that concentration, not a potency): 129%
Compound 4: middle estimate off by 29 percentage points, on the low side, outside the stated range (above it).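

In this assay, the exchange of sec-butyl for cyclohexyl on the amine nitrogen carries over to a second core, giving a number 30 percentage points higher from compound 2 to compound 4 (beyond the scatter). Set beside the earlier step, the change has much the same size on both cores: the same change on two cores in this assay, a number 33 percentage points higher (beyond the scatter) from compound 3 to compound 1 and a number 30 percentage points higher (beyond the scatter) from compound 2 to compound 4, 3 percentage points apart, within the scatter of two such steps This shows that, for these two pairs, the step survives the difference between the cores, but two pairs cannot establish a rule for the whole series, and a read-out at one concentration says nothing about potency or about why cyclohexyl gives the higher number.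

The compounds shown leave open how other groups on the amine nitrogen would behave, such as a cyclopentyl ring, a straight butyl chain or a benzyl group, and so whether ring size or the ring itself matters. They also leave open whether the step would persist on a core carrying other groups on its aromatic rings, such as a fluorine or an amine.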